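Fluorine for Hydroxyl: Cytotoxicity Across Two Related Cores

The compounds below may be only part of what the source reports. "The series", "measured", "known", "first", "only" and "open" are said of these compounds alone.

Compound 1 `C[C@@H]1CC[C@@H]2[C@@H](C1)O[C@@H](c1ccccc1)CC2(C)O` and compound 3 `C[C@@H]1CC[C@@H]2[C@@H](C1)O[C@@H](c1ccccc1)CC2(C)F` share one core and differ in a single place: fluoro in place of hydroxy on a saturated ring carbon. In an ADME assay on MDCK cells (Canis lupus familiaris) for cytotoxicity, read by MTT assay, with a stated time of 48 h (on this read-out higher numbers stand for lower toxicity in this test and lower numbers for higher toxicity in this test), compound 1 gives 580000 nM, and compound 3 gives 65000 nM, which is an 8.9-fold lower number from compound 1 to compound 3 (0.95 log units; beyond the scatter). Compound 2 `COc1cccc([C@H]2CC(C)(O)[C@@H]3CC[C@@H](C)C[C@H]3O2)c1OC` has another core; the difference between the two cores is not broken down here. In this assay compound 2 reaches only a limit of the test, > 937000 nM, not a number. That is the limit of > 937000 nM in this assay, at which 1 of the 3 values shown sits. Compound 4 `COc1cccc([C@H]2CC(C)(F)[C@@H]3CC[C@@H](C)C[C@H]3O2)c1OC` is not yet measured and relates to compound 2 by the same kind of change: fluoro in place of hydroxy on a saturated ring carbon. The places differ only in that the ring atom two ring bonds away bears a large group in compound 4 rather than a phenyl group. The step from compound 2 is expected to be an at least 6.2-fold lower number from compound 2 to compound 4 (0.79 log units; beyond the scatter), because an 8.9-fold lower number from compound 1 to compound 3 (0.95 log units; beyond the scatter). Compound 4 is therefore expected near 150000 nM, between 50000 nM and 937000 nM.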

Compound 4, half-maximal cytotoxic concentration: 180000 nM
For compound 4 the middle estimate is 1.2-fold (0.08 log units) below the measured one; measured number inside the range.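

In this assay, putting fluoro in place of hydroxy on the core of compound 2 gives an at least 5.2-fold lower number from compound 2 to compound 4 (0.71 log units; beyond the scatter). The change therefore lowers the number on both cores shown, and on each the step lies beyond the usual scatter: the same change on two cores in this assay, an 8.9-fold lower number (0.95 log units; beyond the scatter) from compound 1 to compound 3 and an at least 5.2-fold lower number (0.71 log units; beyond the scatter) from compound 2 to compound 4; the limit leaves it open whether they differ. This shows that the direction carried over between these two cores, but it does not give the full size of the step on the second core, and two cores do not make a rule for the whole series.

Still open, as far as these compounds go, is whether another group in the same place, such as an amine or a chloro group, would lower the number in the same way. From the compounds shown here alone, whether the fluoro step would hold on other cores also remains open.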